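Esterification of the Free Hydroxy Group on the Shared Core

The source may hold more compounds than are shown below. What is called first, only, known or untested is meant among the compounds shown, and "the series" means these compounds.

Measured compounds:
compound 1, `C=C1C2=C(C(=O)N1OC)[C@H](OC(=O)CSc1nc3ccccc3s1)[C@@](C)(O)[C@H](CCCCC)O2`, 2300 nM
compound 2, `C=C1C2=C(C(=O)N1OC)[C@H](O)[C@@](C)(O)[C@H](CCCCC)O2`, 10000 nM

The two compounds were tested in a functional assay on Jurkat cells (Homo sapiens) for cytotoxicity, read by MTT assay, with a stated time of 72 h; on this read-out higher numbers stand for weaker inhibition and lower numbers for stronger inhibition. Among the compounds with values here, compound 2 carries a free hydroxy group on the shared core and gives 10000 nM, the higher of the two numbers measured so far. Compound 1, whose core bears an ester in place of that hydroxy group, gives 2300 nM; the gap between the two values lies beyond the usual scatter, so compound 2 stands as the weaker inhibitor of the pair. Within the data shown here, no step between compounds that differ in a single place has been recorded, so the effect of acylation can only be read from these two values.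

Compound 3, `C=C1C2=C(C(=O)N1OC)[C@H](OC(=O)CCCCCl)[C@@](C)(O)[C@H](CCCCC)O2`, has not yet been measured. It differs from compound 2 by (4-chlorobutyl)carbonyl in place of hydrogen on an oxygen on a saturated carbon. Compound 1, the only other ester measured, reaches 2300 nM. On that basis the step of a 3.3-fold lower number from compound 2 to compound 3 (0.52 log units; beyond the scatter) is expected to bring stronger inhibition, beyond the scatter. Compound 3 is therefore estimated at 3000 nM, within a range from 1000 nM to 9000 nM.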

Compound 3, half-maximal inhibitory concentration: 4200 nM
Compound 3: middle estimate off by 1.4-fold (0.15 log units), on the low side; low and high end bracket the measured number.
By their numbers in this assay, from the lowest: compounds 1 and 3 (each within the scatter of the next); then compound 2.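

In this assay, within the data shown here, hydroxy to ((4-chlorobutyl)carbonyl)oxy on an oxygen on a saturated carbon gives a 2.4-fold lower number from compound 2 to compound 3 (0.38 log units; beyond the scatter), a modest step that is the first reading of acylation at this position between compounds differing in one place. Placing 3-chloropropyl in place of (1,3-benzothiazol-2-yl)sulfanyl on a saturated chain carbon bound to a carbonyl carbon gives a 1.8-fold higher number from compound 1 to compound 3 (0.26 log units; within the scatter), within the scatter, so the two esters cannot be told apart in this assay, and an acyl group with no ring serves as well here as the one carrying (1,3-benzothiazol-2-yl)sulfanyl. Nothing among the data at hand accounts for the step from the free hydroxy group to the ester.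

The compounds shown leave open whether the chlorine of the chain contributes anything, which a plain pentanoyl ester on the same oxygen would address, and whether a much shorter acetyl ester would hold the same level. They also leave open how this position would respond to an acyl chain ending in an amine or a carboxylic acid, and whether a carbamate could stand in for the ester.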